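Acetyl to Tosyl on the Sugar Arm of Compound 3

This account rests on a few compounds, and the source may have more. Where it says the series, first, only, none or still open, it means among the compounds named here.

Three glycoside compounds were measured in a functional assay on HeLa cells (Homo sapiens) for antiproliferative activity, read by sulforhodamine B assay, with a stated time of 48 h; a higher number here means a weaker inhibitor of growth, a lower number a stronger inhibitor of growth. Compound 1 `COc1cc(C2=NOC(CO[C@@H]3O[C@H](CSc4ncn[nH]4)[C@H]4OC5(CCCC5)O[C@@H]34)C2)cc(OC)c1OC` gave 38000 nM in this assay. Compound 2 `Nc1nnc(SC[C@H]2O[C@@H](OCc3noc(-c4ccc(Cl)cc4)n3)[C@@H]3OC4(CCCC4)O[C@@H]32)s1` gave 16000 nM in this assay. Compound 3 `CC(=O)OC[C@H]1O[C@@H](OCc2noc(-c3ccc([N+](=O)[O-])cc3)n2)[C@@H]2OC3(CCCC3)O[C@@H]21` gave 17000 nM in this assay. Among these three numbers compound 3 holds the second highest place; its nearest neighbour is compound 2, whose number lies within the scatter of repeated measurements, while compound 1 stands furthest away, with a higher number that lies beyond the scatter. All three compounds therefore sit in a weak region of this assay, and none of them separates sharply from the others apart from compound 1.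

The piece now follows one change. Compound 4 `Cc1ccc(S(=O)(=O)OC[C@H]2O[C@@H](OCc3noc(-c4ccc([N+](=O)[O-])cc4)n3)[C@@H]3OC4(CCCC4)O[C@@H]32)cc1` differs from compound 3 in a single place: (4-methylphenyl)sulfonyl in place of acetyl on an oxygen on a saturated carbon. Among the compounds with values here, no measured pair shows this particular replacement, so its effect can only be guessed from how little the three measured compounds differ from one another.

Compound 4 is expected to give 12000 nM in this assay, within a range from 5000 nM to 30000 nM. This estimate means a step of a 1.4-fold lower number from compound 3 to compound 4 (0.15 log units; within the scatter) that is expected to stay at or near the scatter, with at most a modest move toward a lower number.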

Compound 4, concentration for 50% growth inhibition: > 100000 nM
Compound 4 gave a limit, no number (the forecaster's own chance of this, stated with the estimate: 10%); middle value at least 8.3-fold (0.92 log units) away from the limit.
By their numbers in this assay, from the lowest: compounds 2 and 3 (each within the scatter of the next); then compound 1. At a limit, above all of these: compound 4.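

The three earlier compounds differ from one another in more than one place, so none of them could isolate the group on this oxygen; this pair does. On an oxygen on a saturated carbon, (4-methylphenyl)sulfonyl in place of acetyl gives, in this assay, an at least 5.8-fold higher number from compound 3 to compound 4 (0.76 log units; beyond the scatter), a change beyond the scatter, which shows that the group at this position is not a neutral passenger for growth inhibition, even though the measured compounds had looked so alike. The reading for compound 4 is a limit and not a number, so the step fixes only a minimum size: the limit of > 100000 nM in this assay, at which 1 of the 4 values shown sits.

The compounds shown leave open which part of the (4-methylphenyl)sulfonyl goes with this loss: a benzoyl group or a methanesulfonyl group on the same oxygen would separate the aromatic ring from the sulfonyl, and a free hydroxyl would show what the acetyl itself contributes. From the compounds shown here alone, compounds 1 and 2 differ from compound 3 in more than one place, and whether the step would carry over to their cores also stays open.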